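The source may report more compounds than this note shows. Statements on the series, on what has been measured and on what is new or still open speak of the compounds shown alone.

In an assay on isolated protein for inhibition of aldehyde dehydrogenase 1A1 (Homo sapiens), read by spectrophotometry, tested at 10 uM (on this read-out higher numbers stand for more inhibition at the one concentration tested (going by the name of the read-out) and lower numbers for less inhibition), three members of the series have numbers. Compound 1 `Cc1cccc(Cn2c(OC3CCN(C(=O)c4ccco4)CC3)nc3ccccc32)c1` gives 68.3%, compound 3 `CC(C)CCn1c(CN2CCN(C(=O)C3CC3)CC2)nc2ccccc21` gives 70%, and compound 2 `Cc1cccc(Cn2c(CN3CCN(C(=O)c4cccnc4)CC3)nc3ccccc32)c1` gives 24.5%, the lowest of the three, with both other numbers sitting beyond the scatter above it. Compound 4 `Cc1ccc(C(=O)N2CCN(Cc3nc4ccccc4n3Cc3cccc(C)c3)CC2)cc1` is not yet measured; it differs from compound 2 in one place (4-methylphenyl in place of pyridin-3-yl on a carbonyl carbon). Among the compounds with values here, no measured pair shows this same change, so its size is unknown from the data. Given that compound 2 gives 24.5% while the other carbonyl substituents on the same ring nitrogen sit far higher, a modest rise toward those numbers is expected rather than a fall, though a step no larger than the scatter is plausible. For compound 4 the estimated step is a number 15.5 percentage points higher from compound 2 to compound 4 (beyond the scatter). Compound 4 is thus expected to give 40%, within 15% to 65%.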

Compound 4, a percentage reported as inhibition, at one concentration (the size of the read-out at that concentration, not a potency): 64.9%
Estimate against measurement, compound 4: 24.9 percentage points below; the measured number falls inside the stated range.
By their numbers in this assay, from the lowest: compound 2; then compounds 4, 1 and 3 (each within the scatter of the next).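

With 4-methylphenyl in place of pyridin-3-yl on a carbonyl carbon, the series shows a number 40.4 percentage points higher from compound 2 to compound 4 (beyond the scatter) in this assay and gives its first comparison that differs in one place. This substituent alone can therefore move the read-out by a large step while the rest of the structure stays constant. Nothing on hand explains the step. The pair does not separate the loss of the ring nitrogen from the gain of the methyl. Unsubstituted phenyl would separate them, while 4-methoxyphenyl would test another group at that ring position.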